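Pivaloyl-protected lactones: chain-end variation and growth inhibition

The source may hold more compounds than are shown below. What is called first, only, known or untested is meant among the compounds shown, and "the series" means these compounds.

Measured so far in a functional assay on MOLT-4F cells (Homo sapiens) for antiproliferative activity; on this read-out higher numbers stand for weaker inhibition of growth and lower numbers for stronger inhibition of growth:
- compound 1 `CC(C)(C)C(=O)OCC1(CO)C/C(=C\CCCCCCCCCCCO)C(=O)O1`: 1.34 ug/mL
- compound 2 `CC(C)(C)C(=O)OCC1(CO)C/C(=C/CCCCCCCCCCCCCCC=O)C(=O)O1`: 2.02 ug/mL
- compound 3 `COCCCCCCCCCCC/C=C1\CC(CO)(COC(=O)C(C)(C)C)OC1=O`: 2.38 ug/mL

Compound 1 gives the lowest of the three numbers in this assay, but compound 2 and compound 3 both lie within the usual scatter of it, so no order among the three can be read. Among the measured compounds shown here, the only single-point step among them, a 1.8-fold higher number from compound 1 to compound 3 (0.25 log units; within the scatter), shows that capping the chain-end hydroxyl leaves the read-out essentially unchanged; compound 2, with an aldehyde at a longer chain end, gives a number in the same band.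

Compound 4 `CC(C)(C)C(=O)OCCCCCCCCCCCCCCC/C=C1\CC(CO)(COC(=O)C(C)(C)C)OC1=O` carries a much larger change at the same terminus: 4-(((tert-butyl)carbonyl)oxy)butyl in place of hydroxy on a saturated chain carbon, ten or more bonds along the chain from a double-bonded chain carbon. For the measured compounds named here, the one measured step that touches this position was within the scatter, and nothing among the measured compounds suggests that enlarging the chain end moves the number. The step from compound 1 to compound 4 is therefore expected to stay within the scatter, a 1.4-fold higher number from compound 1 to compound 4 (0.15 log units; within the scatter), with a slight lean toward a higher number given that both compound 2 and compound 3 sit above compound 1. For compound 4 the expected value is 1.9 ug/mL, between 0.8 ug/mL and 4.5 ug/mL.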

Compound 4, concentration for 50% growth inhibition: 0.605 ug/mL
Beside the measured number, compound 4's estimate is 3.1-fold (0.50 log units) above it; measured number below the stated range.
By their numbers in this assay, from the lowest: compound 4; then compounds 1, 2 and 3 (each within the scatter of the next).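

Working notes: in this assay, this chain end can move the number after all, since 4-(((tert-butyl)carbonyl)oxy)butyl in place of hydroxy on a saturated chain carbon, ten or more bonds along the chain from a double-bonded chain carbon, gives a 2.2-fold lower number from compound 1 to compound 4 (0.35 log units; beyond the scatter) and is beyond the scatter, though modest. The same group in place of methoxy gives a 3.9-fold lower number from compound 3 to compound 4 (0.59 log units; beyond the scatter) and points the same way, so the position accepts a far larger group without loss of growth inhibition. No measurement shown bears on the reason for this shift.

The step adds chain length and a terminal (tert-butyl)carbonyl group together, and the compounds shown do not separate the two. Going by these compounds, whether a longer chain ending in hydroxy, an amine or a carboxylic acid at this terminus would shift the number in the same way stays open.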